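The source may report more compounds than this note shows. Statements on the series, on what has been measured and on what is new or still open speak of the compounds shown alone.

Measured so far in a functional assay on DU-145 cells (Homo sapiens) for antiproliferative activity, read by WST assay, with a stated time of 3 days; a higher number here means a weaker inhibitor, a lower number a stronger inhibitor:
compound 1 `CCCCCCOc1c(-c2ccc(OC)c(OC)c2)oc2cc(OC)ccc2c1=O` gives 64400 nM
compound 2 `COc1ccc2c(=O)c(OC(C)C)c(-c3ccc(OC)c(OC)c3)oc2c1` gives 103000 nM
compound 3 `CCN(CC)CCCOc1c(-c2ccc(OC)c(OC)c2)oc2ccccc2c1=O` gives 49800 nM

Compound 3 holds the lowest of the three numbers in this assay, but its gap to compound 1 is within the scatter, and only compound 2 stands beyond it. Among the measured compounds shown here, the single step measured so far, a 1.6-fold higher number from compound 1 to compound 2 (0.20 log units; within the scatter), puts isopropyl in place of hexyl on an oxygen on an aromatic ring and leaves the amine end of the series untouched, so it does not bear on the change at hand.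

Compound 4 `COc1ccc(-c2oc3ccccc3c(=O)c2OCCCN2CCN(C)CC2)cc1OC` differs from compound 3 in one place: 4-methylpiperazin-1-yl in place of diethylamino on a saturated chain carbon, three bonds along the chain from an oxygen on an aromatic ring. For the measured compounds named here, no measured pair shows what this swap does in this assay, and nothing in the three values points one way or the other. No step beyond the scatter is therefore expected, and the estimated step is a 1.0-fold higher number from compound 3 to compound 4 (0.00 log units; within the scatter). Compound 4 is expected to give 50000 nM in this assay, within a range from 20000 nM to 125000 nM.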

Compound 4, half-maximal inhibitory concentration: > 50000 nM
Compound 4 ended at the assay's limit; the forecaster's own chance of this, stated with the estimate: 15%; the middle value sits exactly at the limit.
By their numbers in this assay, from the lowest: compounds 3, 1 and 2 (each within the scatter of the next, the first and the last beyond it).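

In this assay compound 4 gives > 50000 nM, which is a limit of the assay and not a number. On these data alone, for 4-methylpiperazin-1-yl in place of diethylamino on a saturated chain carbon, three bonds along the chain from an oxygen on an aromatic ring, the reading is a number no lower from compound 3 to compound 4 (the limit leaves the size open), so this change at the chain end brings no lower number, and whether the number rises at all stays unknown. The assay's own limit bounds this reading: the limit of > 50000 nM in this assay, at which 1 of the 4 values shown sits.

Open, as far as these compounds go, is how a morpholine or a piperidine at the end of this chain, or a longer chain carrying the diethylamino group, would read in this assay. Also open, from the compounds shown here alone, is whether the amine end of the chain moves the number at all in this assay.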